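The source may report more compounds than this note shows. Statements on the series, on what has been measured and on what is new or still open speak of the compounds shown alone.

Values in an ADME assay on Vero cells (Chlorocebus sabaeus) for cytotoxicity, read by MTT assay, with a stated time of 72 h; on this read-out higher numbers stand for an effect only at larger amounts of compound and lower numbers for an effect already at smaller amounts:
Compound 1 (`Cc1cccc(C(=O)Nc2nc(-c3ccccn3)cs2)c1`): 4100 nM
Compound 2 (`O=C(Nc1nc(-c2ccccn2)cs1)c1cccc(OCc2ccccc2)c1`): 14400 nM
Compound 3 (`COc1cccc(C(=O)Nc2nc(-c3ccccn3)cs2)c1`): 2800 nM

Compound 3 stands at the low end of the three numbers, but it shares that place (a 1.5-fold lower number from compound 1 to compound 3 (0.17 log units; within the scatter)). The clear gap is to the benzyloxy compound (a 5.1-fold lower number from compound 2 to compound 3 (0.71 log units; beyond the scatter)).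

Compound 4 (`CC(=O)c1cccc(C(=O)Nc2nc(-c3ccccn3)cs2)c1`) carries acetyl in place of methoxy on an aromatic carbon, meta to a large group (acetyl in place of methoxy on an aromatic carbon). Among the measured compounds shown here, no measured step involves acetyl, so the evidence is indirect. Exchanging methyl for methoxy at this place left the number within the scatter (a 1.5-fold lower number from compound 1 to compound 3 (0.17 log units; within the scatter)). Only benzyloxy moved it further, and that step was modest (a 3.5-fold higher number from compound 1 to compound 2 (0.55 log units; beyond the scatter)). No step beyond the scatter is therefore expected in this assay, and no direction can be argued with confidence. The expected step is small (a 1.3-fold higher number from compound 3 to compound 4 (0.10 log units; within the scatter)). For compound 4 the estimated value is 3500 nM (expected range 1500 nM to 8000 nM).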

Compound 4, half-maximal effective concentration: 1500 nM
Beside the measured number, compound 4's estimate is 2.3-fold (0.37 log units) above it; the range from low to high includes it.
By their numbers in this assay, from the lowest: compounds 4, 3 and 1 (each within the scatter of the next, the first and the last beyond it); then compound 2.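

Among the compounds shown here, at this aromatic carbon in this assay acetyl, the only group so far with a double bond outside aromatic rings, stays level with methoxy, with a 1.9-fold lower number from compound 3 to compound 4 (0.27 log units; within the scatter) as the step. Against methyl the same group gives a 2.7-fold lower number from compound 1 to compound 4 (0.44 log units; beyond the scatter) and so the only step beyond the scatter towards lower numbers from compound 1, which methoxy did not give. With a 9.6-fold lower number from compound 2 to compound 4 (0.98 log units; beyond the scatter) as the widest step in the series, the span at this one place grows, and benzyloxy in compound 2 stays apart from all three smaller groups on this read-out.

Open, as far as these compounds go, is where an amine or a carboxylic acid at this aromatic carbon would fall in this assay relative to compound 4 and compound 2. No measurement in hand accounts for these steps.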